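The source may report more compounds than this note shows. Statements on the series, on what has been measured and on what is new or still open speak of the compounds shown alone.

Measured so far:
- compound 1, `Oc1ccc(CN(Cc2ccccc2)Cc2ccc(O)c3ncccc23)c2cccnc12`: in a functional assay on U-87MG ATCC cells (Homo sapiens) for antiproliferative activity, with a stated time of 3 days (a higher number here means that more compound is needed for the effect, a lower number that less compound is needed), compound 1 gives < 0.5 uM, which is a limit of the assay rather than a number.
- compound 2, `Cc1ccc(CNCc2ccc(O)c3ncccc23)cc1`: in this assay compound 2 gives > 10 uM, also a limit.
- compound 3, `CC(C)(C)OC(=O)N(Cc1cccc(C(F)(F)F)c1)Cc1ccc(O)c2ncccc12`: in this assay compound 3 gives > 10 uM, again a limit.

Compound 1 therefore stands at the low end of what has been measured, at the limit of < 0.5 uM in this assay, at which 1 of the 3 values shown sits. The other two compounds sit at the opposite end, at the limit of > 10 uM in this assay, at which 2 of the 3 values shown sit. Going by the values given here, no single-change step between two measured compounds exists here, so the values show only that compound 1 is active while compound 2 and compound 3 are not, and no reason for this can be given.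

Compound 4, `Oc1ccc(CN(Cc2ccc(O)c3ncccc23)Cc2ccc(O)c3ncccc23)c2cccnc12`, has not yet been tested. It differs from compound 1 in one place: 8-hydroxyquinolin-5-yl in place of phenyl on a saturated chain carbon bound to an amine nitrogen. Compound 1 already carries two of these 8-hydroxyquinolin-5-yl groups, and compound 4 carries three of them.

Since compound 1 sits at the limit of < 0.5 uM in this assay, at which 1 of the 3 values shown sits, the expected step from compound 1 to compound 4 is small, a step that the limit leaves unreadable from compound 1 to compound 4, in either direction or none beyond the scatter. Compound 4 is estimated at 0.3 uM, with a range from 0.05 uM to 2 uM, and it may well again be reported only as a limit.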

Compound 4, concentration for half-maximal effect: > 10 uM
Compound 4 ended at the assay's limit; the forecaster's own chance of this, stated with the estimate: 60%; middle value at least 33-fold (1.52 log units) away from the limit.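

Putting 8-hydroxyquinolin-5-yl in place of phenyl on a saturated chain carbon bound to an amine nitrogen gives an at least 20-fold higher number from compound 1 to compound 4 (1.30 log units; beyond the scatter) in this assay, and both values behind this step are limits of the assay rather than numbers. Going by these compounds alone, this is the first direct comparison in the set, and it shows that the group at this place matters: with phenyl the compound is active in this assay, while with a third 8-hydroxyquinolin-5-yl group it no longer reaches the tested range, so adding one more copy of this group does not add activity. Nothing measured here explains why the change has this effect.

The step replaces one ring with two and also brings in a ring nitrogen and a hydroxyl group, and the compounds shown do not separate these parts of the change. A naphthyl group or a quinolinyl group without the hydroxyl at this place would help to separate them, and a small methyl group there would show how much of the phenyl ring is needed at all.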